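This account rests on a few compounds, and the source may have more. Where it says the series, first, only, none or still open, it means among the compounds named here.

Measured compounds in an assay on isolated protein for inhibition of malate dehydrogenase, mitochondrial (Sus scrofa), with stated times of 45 min and 30 min; on this read-out higher numbers stand for weaker inhibition and lower numbers for stronger inhibition:
- compound 1 `O=S(=O)(Nc1ccc(-c2nc3ccccc3o2)cc1)c1ccccc1C(F)(F)F`: in this assay compound 1 gives only the limit > 63000 nM.
- compound 2 `CCc1ccc(S(=O)(=O)Nc2ccc(-c3nc4ccccc4o3)cc2)cc1`: in this assay compound 2 gives only the limit > 63000 nM.
- compound 3 `O=S(=O)(Nc1ccc(-c2nc3ccccc3o2)cc1)c1cccc(O)c1`: in this assay compound 3 gives only the limit > 63000 nM.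

Compound 3 therefore stands at the limit of this assay, not at a number, and the two other values shown stand at the same limit (the limit of > 63000 nM in this assay, at which 3 of the 3 values shown sit). Going by the values given here, the one step between measured compounds that differ in one place, a step that the two limits leave unreadable from compound 2 to compound 3, runs between two limits and its size cannot be read.

Compound 4 `O=S(=O)(Nc1ccc(-c2nc3ccccc3o2)cc1)c1ccccc1Cl` carries 2-chlorophenyl in place of 3-hydroxyphenyl on a sulfonyl sulfur. No measured step bears on this change with a readable size; the only step shown, a step that the two limits leave unreadable from compound 2 to compound 3, is itself unreadable, and every value in the series sits at the limit (the limit of > 63000 nM in this assay, at which 3 of the 3 values shown sit). On that basis no step beyond the scatter is expected in this assay, and the most likely outcome for compound 4 is again a limit rather than a number.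

Compound 4 is therefore estimated at 63000 nM, with a range from 20000 nM to 200000 nM. This estimate corresponds to an expected step of a number no higher from compound 3 to compound 4 (the limit leaves the size open).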

Compound 4, half-maximal inhibitory concentration: > 63000 nM
Compound 4: no number, only a limit; the forecaster's own chance of this, stated with the estimate: 85%; the middle value lies on the limit itself.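

Compound 4 gives only a limit in this assay, > 63000 nM. No step from compound 1, compound 2 or compound 3 to compound 4 can be read, because each runs between two limits: the limit of > 63000 nM in this assay, at which 4 of the 4 values shown sit.

The compounds shown leave open whether any group on the sulfonyl sulfur of the shared core gives a measurable number in this assay.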